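The compounds below may be only part of what the source reports. "The series", "measured", "known", "first", "only" and "open" are said of these compounds alone.

Compound 1 `CC(C)(Sc1ccncc1Oc1ccc(C#N)c2ccccc12)C(=O)O` is one of two compounds that have been measured in an assay on HEK293 cells for inhibition of solute carrier family 22 member 12 (Homo sapiens), read by scintillation counting, with stated times of 30 min and 15 min; on this read-out higher numbers stand for weaker inhibition and lower numbers for stronger inhibition. Compound 1 gives 5210 nM, the higher of the two numbers. Going by the values given here, the other, compound 2 `N#Cc1ccc(Nc2cnccc2SCc2ccccc2C(=O)O)c2ccccc12`, gives 240 nM in this assay, a number far enough below that of compound 1 to lie outside the usual scatter; the two structures differ in more than one place, so no single step joins them.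

Compound 3 `N#Cc1ccc(Oc2cnccc2SCCCCC(=O)O)c2ccccc12` has not yet been measured. It is derived from compound 1 by one change: 4-carboxybutyl in place of 1-carboxy-1-methylethyl on a sulfur. The shared core and its nitrile-bearing ring system are kept.

Among the compounds with values here, no measured pair shows this change, so its size is unknown. Compound 3 is expected to give a somewhat lower number than compound 1, and the estimated step of a 2.6-fold lower number from compound 1 to compound 3 (0.42 log units; beyond the scatter) could still fall within the scatter. The estimate for compound 3 is 2000 nM, within a range of 500 nM to 8000 nM.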

Compound 3, half-maximal inhibitory concentration: 4220 nM
Compound 3: the middle estimate sits 2.1-fold (0.32 log units) below what was measured, and the stated range covers the measured number.
By their numbers in this assay, from the lowest: compound 2; then compounds 3 and 1 (each within the scatter of the next).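

In this assay, putting 4-carboxybutyl in place of 1-carboxy-1-methylethyl on a sulfur gives a 1.2-fold lower number from compound 1 to compound 3 (0.09 log units; within the scatter) and so leaves the two compounds indistinguishable on this read-out. Going by these compounds alone, this is the first direct view of this position, and it shows that these two open-chain carboxy groups can be exchanged on the sulfur without a difference that the assay can resolve. Nothing available here offers an explanation for this result.

Within the data shown here, the single step covers only this pair, so it cannot be extended to other substituents on the sulfur. Still open, on these data alone, is how the number would respond to a shorter or longer chain carrying the carboxylic acid, to a chain containing a benzene ring, or to a methyl ester in place of the carboxylic acid.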